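The source may report more compounds than this note shows. Statements on the series, on what has been measured and on what is new or still open speak of the compounds shown alone.

Compound 1 `CC(C#CCn1ccnc1)N1CCCC1=O`: 2 mg/kg
Compound 2 `Cc1cncn1CC#CC(C)N1CCCC1=O`: 0.45 mg/kg
Compound 3 `CCOC(=O)N(C)CC#CCn1ccnc1`: 97 mg/kg

These three were measured in a functional assay on the whole organism for antagonist activity, with Mus musculus as the target; a higher number here means that more compound is needed for the effect, a lower number that less compound is needed. Compound 3 requires the most compound of the three, and how its core differs from the core of compound 1 is not broken down here. Between compound 1 and compound 2 there is one change, (methyl in place of hydrogen on an aromatic carbon), and it brought a 4.4-fold lower number from compound 1 to compound 2 (0.65 log units; beyond the scatter). Compound 4 `CCOC(=O)N(C)CC#CCn1cncc1C` is not yet measured; it differs from compound 3 by the same change, (methyl in place of hydrogen on an aromatic carbon), at the same place. Among the compounds with values here, a step of similar size is expected from compound 3 to compound 4, a 3.9-fold lower number from compound 3 to compound 4 (0.59 log units; beyond the scatter), because the only guide is the step of a 4.4-fold lower number from compound 1 to compound 2 (0.65 log units; beyond the scatter), seen once on a different core. Compound 4 is therefore estimated at 25 mg/kg, with a range from 8 mg/kg to 75 mg/kg.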

Compound 4, dose for half-maximal effect: 66 mg/kg
The estimate for compound 4 lay 2.6-fold (0.42 log units) below the measured number, within the range that was stated.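

Set on the core of compound 3, methyl in place of hydrogen on an aromatic carbon gave a 1.5-fold lower number from compound 3 to compound 4 (0.17 log units; within the scatter) in this assay, so this pair cannot be told apart. The two steps differ: the same change on two cores in this assay, a 4.4-fold lower number (0.65 log units; beyond the scatter) from compound 1 to compound 2 and a 1.5-fold lower number (0.17 log units; within the scatter) from compound 3 to compound 4, 3.0-fold (0.48 log units) apart, beyond the scatter of two such steps. The size of the step seen on the core of compound 1 therefore did not carry over to the core of compound 3, but with a single pair on each core this does not show what in the core sets the size, or how the change would behave on a further core.

The compounds shown leave open how an ethyl group or a chlorine on the same aromatic carbon would fare on either core. Also open, from the compounds shown here alone, is whether, on a core carrying a plain amine in place of the carbonyl, the methyl step would resemble that on the core of compound 1 or that on the core of compound 3.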